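Swapping 3-fluorophenyl for 4-fluorophenyl on a sulfur

This account rests on a few compounds, and the source may have more. Where it says the series, first, only, none or still open, it means among the compounds named here.

Measured so far in a functional assay on HCT-116 cells (Homo sapiens) for inhibition, read by CCK-8 assay, with a stated time of 72 h, tested at 2 uM (a higher number here means more inhibition of growth at the concentration tested, a lower number less inhibition of growth), are two compounds:
Compound 1 `Nc1ccccc1NC(=O)/C=C/c1ccc(CSc2cccc(F)c2)cc1` gives 7.95%
Compound 2 `Nc1ccccc1NC(=O)c1ccc(CSc2cccc(F)c2)cc1` gives 5.5%

Compound 1 and compound 2 stand within the usual scatter of each other, and neither can be ranked above the other. Both show only slight inhibition of growth in this assay at the concentration tested. The next compound is compound 3 `Nc1ccccc1NC(=O)/C=C/c1ccc(CSc2ccc(F)cc2)cc1`, which has 4-fluorophenyl in place of 3-fluorophenyl on a sulfur, a swap counted as 4-fluorophenyl in place of 3-fluorophenyl on a sulfur with the same atoms joined differently. Among the measured compounds shown here, no measured pair shows what this swap does. With compound 1 at 7.95% as the only reference, no step beyond the scatter is expected in this assay from this change. The estimated a number 0.1 percentage points higher from compound 1 to compound 3 (within the scatter) lies within the scatter. For compound 3 the estimate is 8% with an expected range from 1% to 20% in this measurement.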

Compound 3, percent growth inhibition at one concentration: 14.1%
For compound 3 the middle estimate is 6.1 percentage points below the measured one; low and high end bracket the measured number.
By their numbers in this assay, from the lowest: compounds 2, 1 and 3 (each within the scatter of the next).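

In this assay, among the compounds shown here, the swap of 3-fluorophenyl for 4-fluorophenyl on a sulfur gives a number 6.2 percentage points higher from compound 1 to compound 3 (within the scatter) and is the first reading of any change at this position. Moving the fluorine around the ring, with the same atoms joined differently, therefore produces no step that can be told apart from repeated measurement, and compound 1 and compound 3 cannot be ranked. Nothing available bears on why this swap reads as it does.

Going by these compounds, it remains open what a phenyl carrying a methoxy group or a chlorine atom, or an unsubstituted phenyl, would give on this sulfur. On these data alone, it is equally open whether the same swap would read alike on the core of compound 2, or at a concentration where growth is inhibited more strongly.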